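The compounds below may be only part of what the source reports. "The series", "measured", "known", "first", "only" and "open" are said of these compounds alone.

Compound 1 `CN1CCN(C[C@H]2CN(c3ccc(-n4cc(-c5ccccn5)cn4)c(F)c3)C(=O)O2)CC1` gives 70 ug/mL in an ADME assay on HEK293-A cells (Homo sapiens) for cytotoxicity, read by MTT assay, with a stated time of 48 h; on this read-out higher numbers stand for weaker inhibition and lower numbers for stronger inhibition.
Compound 2 `CC(=O)OC[C@H]1CN(c2ccc(-n3cc(-c4ccccn4)cn3)c(F)c2)C(=O)O1` sits at a limit of this assay, > 400 ug/mL.
Compound 3 `O=CNC[C@H]1CN(c2ccc(-n3cc(-c4ccccn4)cn3)c(F)c2)C(=O)O1` likewise sits at a limit, > 400 ug/mL.

Compound 3 thus stands at the top of the shown values, sharing the limit with compound 2 (the limit of > 400 ug/mL in this assay, at which 2 of the 3 values shown sit). The measured steps run an at least 5.7-fold higher number from compound 1 to compound 2 (0.75 log units; beyond the scatter) and an at least 5.7-fold higher number from compound 1 to compound 3 (0.75 log units; beyond the scatter), while a step that the two limits leave unreadable from compound 2 to compound 3. Compound 4 `O=C1O[C@@H](CNC(=O)C(F)(F)F)CN1c1ccc(-n2cc(-c3ccccn3)cn2)c(F)c1` arises from compound 3 by trifluoromethyl in place of hydrogen on a carbonyl carbon. No measured step touches the carbonyl carbon, and both shown changes on the saturated chain carbon ended at the limit, so the step to compound 4 in this assay is expected to be a number no higher from compound 3 to compound 4 (the limit leaves the size open). Compound 4 is therefore estimated at 400 ug/mL, within 150 ug/mL to 400 ug/mL, most likely again as a limit.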

Compound 4, half-maximal inhibitory concentration: > 400 ug/mL
Compound 4: a limit, no number; the forecaster's own chance of this, stated with the estimate: 75%; the middle value lies on the limit itself.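

In this assay compound 4 also sits at a limit, > 400 ug/mL, so trifluoromethyl on the carbonyl carbon brings no measurable drop in the number. The ((trifluoromethyl)carbonyl)amino group thus joins acetoxy and formylamino in the contrast with 4-methylpiperazin-1-yl, with an at least 5.7-fold higher number from compound 1 to compound 4 (0.75 log units; beyond the scatter). The steps among compound 2, compound 3 and compound 4 cannot be read, all three values being the same limit: the limit of > 400 ug/mL in this assay, at which 3 of the 4 values shown sit.

The compounds shown leave open how far past this limit those three compounds lie. They also leave open whether a primary amine on the saturated chain carbon would lower the number as 4-methylpiperazin-1-yl does.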